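Swapping a Hydroxymethyl for a Butynyl on Deoxyuridine

The source may report more compounds than this note shows. Statements on the series, on what has been measured and on what is new or still open speak of the compounds shown alone.

Of the compounds shown here, three have so far been measured in an ADME assay on L1210/0 cells (Mus musculus) for cytotoxicity, with a stated time of 48 h; on this read-out higher numbers stand for weaker inhibition and lower numbers for stronger inhibition. Compound 2 `O=c1[nH]c(=O)n([C@H]2C[C@H](O)[C@@H](CO)O2)cc1CO` gives 9180 nM, the lowest number of the set. Compound 1 `CC1=C(C)C(=O)C(c2cn([C@H]3C[C@H](O)[C@@H](CO)O3)c(=O)[nH]c2=O)=C(C)C1=O` gives 174000 nM, a number standing above that of compound 2 by more than the usual scatter. Compound 3 `COc1cc(-c2cn([C@H]3C[C@H](O)[C@@H](CO)O3)c(=O)[nH]c2=O)c(OC)c(C)c1C` reaches no number at all but only (the limit of > 200000 nM in this assay, at which 1 of the 3 values shown sits), recorded as > 200000 nM. Compound 4 `CCC#Cc1cn([C@H]2C[C@H](O)[C@@H](CO)O2)c(=O)[nH]c1=O` has not yet been measured; it differs from compound 2 in one place: but-1-yn-1-yl in place of hydroxymethyl on an aromatic carbon. Among the compounds with values here, no step between measured compounds that changes only one group is available, so the size of this change is uncertain. For compound 4 a somewhat weaker inhibition is expected, estimated at 25000 nM with a range from 3000 nM to 150000 nM. This expectation means a step of a 2.7-fold higher number from compound 2 to compound 4 (0.44 log units; beyond the scatter), beyond the scatter.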

Compound 4, half-maximal inhibitory concentration: > 200000 nM
Compound 4 gave a limit, no number; the forecaster's own chance of this, stated with the estimate: 20%; at least 8.0-fold (0.90 log units) between middle value and limit.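

In this assay, a single change at this position is enough to shift the read-out far beyond the scatter: but-1-yn-1-yl in place of hydroxymethyl gives an at least 21-fold higher number from compound 2 to compound 4 (1.33 log units; beyond the scatter). The earlier compounds shown here offered no pair differing in one place, so they could not show this. Compound 4 stands at a limit of the assay, not at a number: the limit of > 200000 nM in this assay, at which 2 of the 4 values shown sit.

As far as these compounds go, it remains open whether the hydroxyl, the chain length or the triple bond matters most. An ethyl or aminomethyl group at this position would help separate these.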